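The compounds below may be only part of what the source reports. "The series", "measured", "known", "first", "only" and "open" are said of these compounds alone.

Measured compounds:
Compound 1, `Cc1ccc(-n2nc(C(=O)Nc3ccc(Oc4ncnc5ccsc45)c(F)c3)c(C)cc2=O)cc1`, in a functional assay on HepG2 cells (Homo sapiens) for cytotoxicity, read by MTT assay, with a stated time of 72 h (on this read-out higher numbers stand for weaker inhibition and lower numbers for stronger inhibition), gives 17300 nM.
Compound 2, `Cc1cc(=O)n(-c2ccc(Br)cc2F)nc1C(=O)Nc1ccc(Oc2ncnc3sccc23)c(F)c1`, gives 13800 nM.
Compound 3, `Cc1cc(=O)n(-c2ccccc2OC(F)(F)F)nc1C(=O)Nc1ccc(Oc2ncnc3sccc23)c(F)c1`, gives only a limit of the assay, > 40000 nM.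

Compound 3 thus sits at the limit (the limit of > 40000 nM in this assay, at which 1 of the 3 values shown sits), with no number of its own. Compound 4, `Cc1ccc(-n2nc(C(=O)Nc3ccc(Oc4ncnc5sccc45)c(F)c3)c(C)cc2=O)cc1`, is the unmeasured partner: 4-methylphenyl in place of 2-(trifluoromethoxy)phenyl on an aromatic nitrogen. Within the data shown here, one measured step bears on this position: an at least 2.8-fold higher number from compound 2 to compound 3 (0.46 log units; beyond the scatter), which went upward to the limit. Compound 1 also carries a 4-methylphenyl group and gives 17300 nM. A step back downward from the limit is therefore expected, an at least 2.5-fold lower number from compound 3 to compound 4 (0.39 log units; beyond the scatter). The estimate for compound 4 is 16000 nM, with an expected range from 6000 nM to 40000 nM.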

Compound 4, half-maximal inhibitory concentration: > 40000 nM
Compound 4: no number, only a limit; the forecaster's own chance of this, stated with the estimate: 15%; middle value at least 2.5-fold (0.39 log units) from the limit.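

In this assay, the 4-methylphenyl group alone does not fix the result, since exchanging only the group on the oxygen gives an at least 2.3-fold higher number from compound 1 to compound 4 (0.36 log units; beyond the scatter). On the shared core, 4-methylphenyl in place of 4-bromo-2-fluorophenyl gives an at least 2.8-fold higher number from compound 2 to compound 4 (0.46 log units; beyond the scatter). The change between compound 3 and compound 4 cannot be read, as each gives only a limit: the limit of > 40000 nM in this assay, at which 2 of the 4 values shown sit.

From the compounds shown here alone, how far compound 3 and compound 4 lie beyond that limit stays open. So does whether a 4-aminophenyl group or a longer chain on this nitrogen would give a measurable number on this core.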